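Chain Extension on an Acrylamide Side Chain: Forecast for Compound 4

The source may hold more compounds than are shown below. What is called first, only, known or untested is meant among the compounds shown, and "the series" means these compounds.

The measured compounds and their values:

Compound 1, `CC/C=C/C(=O)Nc1cccc(Oc2nc(Nc3cccc(C#N)c3)nc3c2CSCC3)c1`: in a functional assay on A549 cells (Homo sapiens) for antiproliferative activity, read by MTT assay, with a stated time of 72 h (on this read-out lower numbers stand for stronger inhibition and higher numbers for weaker inhibition), compound 1 gives 10100 nM.
Compound 2, `CC(C)/C=C/C(=O)Nc1cccc(Oc2nc(Nc3cccc(C#N)c3)nc3c2CSCC3)c1`: in this assay compound 2 gives 35900 nM.
Compound 3, `CC/C=C/C(=O)Nc1cccc(Oc2nc(Nc3ccc(OC)cc3)nc3c2CSCC3)c1`: in this assay compound 3 gives 20100 nM.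

The three compounds share a common core and differ at two places. Between compound 1 and compound 3 the difference lies on the aryl amine, (4-methoxyphenyl in place of 3-cyanophenyl on a nitrogen on an aromatic ring), and it made a 2.0-fold higher number from compound 1 to compound 3 (0.30 log units; within the scatter). Between compound 1 and compound 2 the difference lies on the unsaturated amide chain, (methyl in place of hydrogen on a saturated chain carbon bound to a double-bonded chain carbon and a saturated chain carbon), and it made a 3.6-fold higher number from compound 1 to compound 2 (0.55 log units; beyond the scatter).

Compound 4, `CCC/C=C/C(=O)Nc1cccc(Oc2nc(Nc3ccc(OC)cc3)nc3c2CSCC3)c1`, has not yet been measured. It carries the core of compound 3 and differs from it by methyl in place of hydrogen on a saturated chain carbon, two bonds along the chain from a double-bonded chain carbon. This is the same kind of change as that from compound 1 to compound 2, but not the same: in the earlier pair the methyl enters on a saturated chain carbon bound to a double-bonded chain carbon and a saturated chain carbon, whereas here it enters on a saturated chain carbon two bonds along the chain from a double-bonded chain carbon, so the chain grows longer rather than branching.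

For the measured compounds named here, because a 3.6-fold higher number from compound 1 to compound 2 (0.55 log units; beyond the scatter) was modest and beyond the scatter, a step in the same direction but somewhat smaller is expected here, since the only precedent concerns a different place on the chain and the cores also differ by 4-methoxyphenyl in place of 3-cyanophenyl on a nitrogen on an aromatic ring. The step from compound 3 to compound 4 is estimated at a 2.0-fold higher number from compound 3 to compound 4 (0.30 log units; within the scatter). For compound 4 the expected value is 40000 nM, with a range estimated from 15000 nM to 100000 nM.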

Compound 4, half-maximal inhibitory concentration: 11900 nM
For compound 4 the middle estimate is 3.4-fold (0.53 log units) above the measured one; the measured number lies below the stated range.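

In this assay, methyl in place of hydrogen on a saturated chain carbon, two bonds along the chain from a double-bonded chain carbon, gave a 1.7-fold lower number from compound 3 to compound 4 (0.23 log units; within the scatter), so this read-out does not separate compound 3 from compound 4. Set beside the earlier step, the result shows that this kind of change did not carry over from one core to the other as a fixed step: the same change on two cores in this assay, a 3.6-fold higher number (0.55 log units; beyond the scatter) from compound 1 to compound 2 and a 1.7-fold lower number (0.23 log units; within the scatter) from compound 3 to compound 4, 6.0-fold (0.78 log units) apart, beyond the scatter of two such steps It does not show what accounts for the gap, since the two pairs differ both in the group on the aryl amine, 3-cyanophenyl or 4-methoxyphenyl, and in where the methyl enters, which branches the chain in compound 2 and lengthens it in compound 4, and two pairs give no rule for the series.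

The compounds shown leave open how the pent-1-en-1-yl chain of compound 4 would read on the core of compound 1 and how the branched chain of compound 2 would read on the core of compound 3, two pairings that would separate the effect of the core from that of the place on the chain. They also leave open how a longer chain, or a chain carrying an amine, would read in this assay on either core.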